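Side-chain variation on a shared core: compounds 1 to 3

The source may hold more compounds than are shown below. What is called first, only, known or untested is meant among the compounds shown, and "the series" means these compounds.

Measured so far:
compound 1, `CCCCC#Cc1cn([C@H]2C[C@H](O)[C@@H](CO)O2)c(=O)[nH]c1=O`: 1000 ug/mL
compound 2, `CCCCCCc1cn([C@H]2C[C@H](O)[C@@H](CO)O2)c(=O)[nH]c1=O`: 301 ug/mL

In a functional assay on L1210 cells (Mus musculus) (a higher number here means a weaker inhibitor, a lower number a stronger inhibitor), compound 1 gives 1000 ug/mL, while compound 2 gives 301 ug/mL. For the measured compounds named here, compound 2 thus holds the lowest of the two numbers; its nearest neighbour is compound 1, and the single measured step, a 3.3-fold lower number from compound 1 to compound 2 (0.52 log units; beyond the scatter), separates them.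

Compound 3, `COCC#Cc1cn([C@H]2C[C@H](O)[C@@H](CO)O2)c(=O)[nH]c1=O`, is the next candidate. It differs from compound 2 in one place: 3-methoxyprop-1-yn-1-yl in place of hexyl on an aromatic carbon. Going by the values given here, the change restores a triple bond outside the aromatic ring, which is the feature that the one relevant step, a 3.3-fold lower number from compound 1 to compound 2 (0.52 log units; beyond the scatter), removed; that step was modest. On that basis a modest rise in this assay is expected for compound 3, though the new chain also brings a hydrogen-bond acceptor for which no comparison exists.

Compound 3 is expected to give about 800 ug/mL, plausibly between 250 ug/mL and 3000 ug/mL. The expected step is a 2.7-fold higher number from compound 2 to compound 3 (0.42 log units; beyond the scatter).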

Compound 3, concentration for 50% inhibition: 254 ug/mL
Estimate against measurement, compound 3: 3.1-fold (0.50 log units) above, and the stated range covers the measured number.
By their numbers in this assay, from the lowest: compounds 3 and 2 (each within the scatter of the next); then compound 1.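

Working notes: in this assay, the triple bond outside the aromatic ring does not fix the number on its own: with that bond kept, methoxy in place of propyl on the saturated chain carbon bound to a triple-bonded carbon gives a 3.9-fold lower number from compound 1 to compound 3 (0.60 log units; beyond the scatter). At this aromatic carbon, 3-methoxyprop-1-yn-1-yl in place of hexyl gives a 1.2-fold lower number from compound 2 to compound 3 (0.07 log units; within the scatter), so these two quite different side chains cannot be told apart in this read-out. No supporting data bear on the reason for either step.

Open, as far as these compounds go, is whether the oxygen or the shorter chain carries the step from the alkyne with the propyl end, since the methoxy swap alters both. A hydroxyl or an amine at the chain end, or a longer chain ending in methoxy, would separate these readings.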